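Longer Chain and Tolerance on Kidney Cells

The source may hold more compounds than are shown below. What is called first, only, known or untested is meant among the compounds shown, and "the series" means these compounds.

Compound 3 `CCCCNc1cncc(C(=O)NCc2ccccc2)n1` gives 100000 nM in an ADME assay on MDCK cells (Canis lupus familiaris) for cytotoxicity, read by microscopy, with a stated time of 6 days (a higher number here means that more compound is tolerated, a lower number that less compound is tolerated), the highest of the two numbers reported in this series. Its nearest neighbour, compound 1 `CCCCCCNc1cncc(C(=O)NCc2ccccc2)n1`, gives 20000 nM in this assay. Compound 2 `O=C(NCc1ccccc1)c1nccnc1Cl` stands at "not determined" (no result reported) in this assay, so it cannot be placed beside the others.

Going by the values given here, the only step that can be followed is a 5.0-fold higher number from compound 1 to compound 3 (0.70 log units; beyond the scatter). It shows that shortening the chain on the ring nitrogen raised the tolerated concentration by a modest amount beyond the scatter. Compound 4 `CCCCCCCCNc1cncc(C(=O)NCc2ccccc2)n1` differs from compound 3 by the change (butyl in place of hydrogen on a saturated chain carbon, four bonds along the chain from a nitrogen on an aromatic ring). This is the reverse direction of the measured step and carries the chain further than compound 1 does, so a lower number is expected, likely of at least the same size as the measured step, because compound 1 already sits at 20000 nM with a chain two carbons shorter than that of compound 4.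

For compound 4 in this assay the expected value is 6000 nM, with a range of 2000 nM to 20000 nM. The expected step is therefore a 17-fold lower number from compound 3 to compound 4 (1.22 log units; beyond the scatter), a clear decrease beyond the scatter.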

Compound 4, minimum cytotoxic concentration: 4000 nM
For compound 4 the middle estimate is 1.5-fold (0.18 log units) above the measured one; low and high end bracket the measured number.
By their numbers in this assay, from the lowest: compound 4; then compound 1; then compound 3.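

The result shows that the fall in tolerated concentration in this assay continues as the chain at this position grows, with a 25-fold lower number from compound 3 to compound 4 (1.40 log units; beyond the scatter) being large and beyond the scatter. It also shows that the fall does not level off at the hexyl stage: adding ethyl at the place six bonds along the chain gives a 5.0-fold lower number from compound 1 to compound 4 (0.70 log units; beyond the scatter), matching in size the earlier step of a 5.0-fold higher number from compound 1 to compound 3 (0.70 log units; beyond the scatter), so the order follows chain length in all three compounds with a number, and none of them goes against it. Nothing available explains why the longer chain is tolerated less well.

The compounds shown leave open whether a still longer chain would lower the number further or whether the trend would flatten, and whether a propyl or methyl chain at this position would be tolerated better than compound 3. They also leave open how a chain of similar length would behave if it carried an amine or a carboxylic acid, or if it contained a ring such as phenyl.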